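From nitro to fluoro on an aromatic carbon

The compounds below may be only part of what the source reports. "The series", "measured", "known", "first", "only" and "open" are said of these compounds alone.

- compound 1 `COc1ccc(C(=O)/C=C\Nc2ccc(-c3nc4cc(OC)c(OC)c(OC)c4s3)cc2C)cc1F`: 2900 nM
- compound 2 `COc1ccc(C(=O)/C=C\Nc2ccc(-c3nc4cc(OC)c(OC)c(OC)c4s3)cc2)cc1[N+](=O)[O-]`: 17100 nM

In a functional assay on MDA-MB-231 cells (Homo sapiens) for antiproliferative activity, read by sulforhodamine B assay, with a stated time of 48 h (on this read-out lower numbers stand for stronger inhibition and higher numbers for weaker inhibition), compound 2 holds the higher of the two numbers, so it is the weaker inhibitor of this pair, beyond the scatter. Compound 3 `COc1ccc(C(=O)/C=C\Nc2ccc(-c3nc4cc(OC)c(OC)c(OC)c4s3)cc2)cc1F` arises from compound 2 through (fluoro in place of nitro on an aromatic carbon), with fluoro in place of nitro on an aromatic carbon, ortho to a methoxy group. Compound 1 also carries the 3-fluoro-4-methoxyphenyl group and gives 2900 nM in this assay, which points to a lower number. The expected 5.7-fold lower number from compound 2 to compound 3 (0.76 log units; beyond the scatter) is a drop beyond the scatter. For compound 3 the estimated value is 3000 nM, within an expected range of 1000 nM to 9000 nM overall.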

Compound 3, half-maximal inhibitory concentration: 16500 nM
Beside the measured number, compound 3's estimate is 5.5-fold (0.74 log units) below it; the measured number lies above the stated range.
By their numbers in this assay, from the lowest: compound 1; then compounds 3 and 2 (each within the scatter of the next).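

In this assay, fluoro in place of nitro on this aromatic carbon, ortho to a methoxy group, does not separate the two compounds (a 1.0-fold lower number from compound 2 to compound 3 (0.02 log units; within the scatter)), so the two groups cannot be told apart here. The step that does count lies elsewhere: hydrogen in place of methyl on an aromatic carbon gives a 5.7-fold higher number from compound 1 to compound 3 (0.76 log units; beyond the scatter) and not the fluoro group, so the low number of compound 1 goes with its methyl. On these data alone, whether an amine or a carboxylic acid on this carbon would fall with nitro and fluoro stays open. Nothing available explains either step.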